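The source may report more compounds than this note shows. Statements on the series, on what has been measured and on what is new or still open speak of the compounds shown alone.

Compound 2 `CCN(CC)C(=O)CN(c1ccc(C)cc1)S(=O)(=O)c1ccc(OC)c(OC)c1` sits at a limit of a functional assay on CHO cells for inhibition of Orexin/Hypocretin receptor type 1 (Homo sapiens), read by FLIPR and calcium flux (a higher number here means a weaker inhibitor, a lower number a stronger inhibitor), with a reading of > 10000 nM. Compound 3 `CCN(CC)C(=O)CN(c1ccc(C)cc1)S(=O)(=O)c1ccc(OC)cc1` likewise returns only a limit, > 10000 nM. Both rest on (the limit of > 10000 nM in this assay, at which 2 of the 3 values shown sit), so the step that the two limits leave unreadable from compound 2 to compound 3 cannot be sized. For the measured compounds named here, compound 1 `CCN(CC)C(=O)CN(c1cc2c(C)nsc2cc1Cl)S(=O)(=O)c1ccc(OC)c(OC)c1` gives 29 nM in this assay, and the step of an at least 340-fold higher number from compound 1 to compound 2 (2.53 log units; beyond the scatter) is the one measured change that bears on the unmeasured compound 4 `CCN(CC)C(=O)CN(c1cc(Cl)ccc1N(C)C)S(=O)(=O)c1ccc(OC)c(OC)c1`. Compound 4 differs from compound 2 by 5-chloro-2-(dimethylamino)phenyl in place of 4-methylphenyl on a sulfonamide nitrogen. The entering group carries a chlorine and a nitrogen, as does the group of compound 1, yet it is a single ring. The expected step is therefore a gain of an at least 16-fold lower number from compound 2 to compound 4 (1.22 log units; beyond the scatter), smaller than the loss in an at least 340-fold higher number from compound 1 to compound 2 (2.53 log units; beyond the scatter). Compound 4 is estimated at 600 nM, between 60 nM and 6000 nM.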

Compound 4, half-maximal inhibitory concentration: 4880 nM
Estimate against measurement, compound 4: 8.1-fold (0.91 log units) below, within the range that was stated.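

A single aromatic ring on the sulfonamide nitrogen now gives a number rather than a limit in this assay, with an at least 2.0-fold lower number from compound 2 to compound 4 (0.31 log units; beyond the scatter). Compound 2 stands only at a limit, so this step has no upper size: the limit of > 10000 nM in this assay, at which 2 of the 4 values shown sit. Chlorine and a dimethylamino nitrogen on one ring still fall well short of the group in compound 1, with a 170-fold higher number from compound 1 to compound 4 (2.23 log units; beyond the scatter).

Going by these compounds, it remains open whether the chlorine or the dimethylamino group accounts for the gain. On these data alone, the effect of a primary amine or a methoxy group in place of dimethylamino also remains open.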